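Notes on an iodo replacement in a ribonucleoside series

A few compounds are considered here, and "the series" means these few. Any claim that something is new, unique, unknown or untested is made for them only; others in the source may bear on it.

Compound 1 `Nc1nc(N)c2c(-c3ccsc3)cn([C@@H]3O[C@H](CO)[C@@H](O)[C@H]3O)c2n1` in a functional assay on CEM-DNR-bulk cells (Homo sapiens), read by MTT assay, with a stated time of 72 h (on this read-out higher numbers stand for weaker inhibition and lower numbers for stronger inhibition), gives only the limit > 20000 nM. Compound 2 `COc1ncnc2c1c(I)cn2[C@@H]1O[C@H](CO)[C@@H](O)[C@H]1O` in this assay gives only the limit > 20000 nM. Compound 3 `Cc1nc(N)c2c(-c3ccsc3)cn([C@@H]3O[C@H](CO)[C@@H](O)[C@H]3O)c2n1` in this assay gives only the limit > 20000 nM.

Compound 3 thus stands at the limit of this assay, where all three measured compounds sit, as stated by the limit of > 20000 nM in this assay, at which 3 of the 3 values shown sit. Among the compounds with values here, the one measured step, a step that the two limits leave unreadable from compound 1 to compound 3, is therefore not readable. Compound 4 `Cc1nc(N)c2c(I)cn([C@@H]3O[C@H](CO)[C@@H](O)[C@H]3O)c2n1` arises from compound 3 by iodo in place of thiophen-3-yl on an aromatic carbon. Within the data shown here, no measured step bears on this change; compound 2, which also carries iodo on the same ring position, sits at the limit as well. Compound 4 is therefore expected to remain at the limit, estimated at 30000 nM with a range of 10000 nM to 100000 nM. The expected step is a step that the limit leaves unreadable from compound 3 to compound 4, that is, none readable beyond the scatter.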

Compound 4, half-maximal inhibitory concentration: 3480 nM
Compound 4: middle estimate off by 8.6-fold (0.94 log units), on the high side, and the stated range ends above it.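

In this assay, within the data shown here, iodo in place of thiophen-3-yl gives an at least 5.7-fold lower number from compound 3 to compound 4 (0.75 log units; beyond the scatter) and is the only readable step so far. Among these compounds, the substituent at this position can therefore move the read-out, which the earlier compounds could not show, since the step between compound 1 and compound 3 cannot be read. Compound 4 alone stands off the limit: the limit of > 20000 nM in this assay, at which 3 of the 4 values shown sit.

As far as these compounds go, whether bromo, ethynyl or an amine at this position would match iodo remains open. Also open, from the compounds shown here alone, is whether amino in place of methyl would keep the gain with iodo present.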